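Aryl swap on sulfone and thioether enones, DU-145 growth

The compounds below may be only part of what the source reports. "The series", "measured", "known", "first", "only" and "open" are said of these compounds alone.

Measured in a functional assay on DU-145 cells (Homo sapiens) for inhibition, read by trypan blue exclusion, with a stated time of 96 h; on this read-out lower numbers stand for stronger inhibition of growth and higher numbers for weaker inhibition of growth:
compound 1 `Cc1ccc(CS(=O)(=O)/C(=C/c2cc(C)cc(C)c2)C(=O)c2ccc(Cl)cc2)cc1` gives 10000 nM.
compound 2 `Cc1ccc(CS(=O)(=O)/C(=C/c2ccc(N(C)C)cc2)C(=O)c2ccc(Cl)cc2)cc1` gives 50000 nM.
compound 3 `CN(C)c1ccc(/C=C(/SCc2ccc(Cl)cc2)C(=O)c2ccc(Cl)cc2)cc1` reaches only the limit of the assay, > 100000 nM.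

Within this assay the change 3,5-dimethylphenyl in place of 4-(dimethylamino)phenyl on a double-bonded chain carbon bound to a double-bonded chain carbon gives a 5.0-fold lower number from compound 2 to compound 1 (0.70 log units; beyond the scatter). The difference between the cores of compound 2 and compound 3 is not broken down here. Compound 4 `Cc1cc(C)cc(/C=C(/SCc2ccc(Cl)cc2)C(=O)c2ccc(Cl)cc2)c1` is not yet measured; it carries the same change, (3,5-dimethylphenyl in place of 4-(dimethylamino)phenyl on a double-bonded chain carbon bound to a double-bonded chain carbon), on the core of compound 3. For compound 3 only a limit is known, (the limit of > 100000 nM in this assay, at which 1 of the 3 values shown sits), so any step from it is anchored loosely. A step of about the earlier size is expected for compound 4, an at least 2.5-fold lower number from compound 3 to compound 4 (0.39 log units; beyond the scatter), resting on a 5.0-fold lower number from compound 2 to compound 1 (0.70 log units; beyond the scatter). Compound 4 is therefore estimated near 40000 nM, roughly 10000 nM to 200000 nM, with a real chance that only a limit is returned.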

Compound 4, concentration for 50% growth inhibition: 10000 nM
The estimate for compound 4 lay 4.0-fold (0.60 log units) above the measured number; the range from low to high includes it.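

In this assay, 3,5-dimethylphenyl in place of 4-(dimethylamino)phenyl lowers the number on both the sulfone and the thioether cores, and on the thioether core the change gives an at least 10-fold lower number from compound 3 to compound 4 (1.00 log units; beyond the scatter). The direction therefore carries over in these two pairs. Compound 3 stands only at a limit of the assay, > 100000 nM, so the step on its core has no upper bound and the two sizes cannot be ranked: the same change on two cores in this assay, a 5.0-fold lower number (0.70 log units; beyond the scatter) from compound 2 to compound 1 and an at least 10-fold lower number (1.00 log units; beyond the scatter) from compound 3 to compound 4; the limit leaves it open whether they differ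

Two pairs set no rule for other cores in the series. As far as these compounds go, whether an amine or a carboxylic acid on the same double-bonded chain carbon would follow this direction on both cores remains open.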